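Chloro in place of methoxy: from compound 3 to compound 4

A few compounds are considered here, and "the series" means these few. Any claim that something is new, unique, unknown or untested is made for them only; others in the source may bear on it.

In a functional assay on MDA-MB-231 cells (Homo sapiens), read by microscopy and transwell migration, with a stated time of 24 h (a higher number here means a weaker inhibitor, a lower number a stronger inhibitor), compound 3 (`COc1ccc(C(=O)/N=c2\scc(-c3cc(OC)c(OC)c(OC)c3)n2C)cc1`) gives 8040 nM and stands among the higher numbers of the series. Within the data shown here, compound 1 (`COc1ccccc1C(=O)Nc1nc(-c2cc(OC)c(OC)c(OC)c2)cs1`) gives 8500 nM within the scatter of that value, while compound 2 (`COc1cc(-c2cs/c(=N\C(=O)c3ccccc3)n2C)cc(OC)c1OC`) gives 1070 nM as the lowest number so far. Compound 4 (`COc1cc(-c2cs/c(=N\C(=O)c3ccc(Cl)cc3)n2C)cc(OC)c1OC`) differs from compound 3 by one change, para to a large group (chloro in place of methoxy on an aromatic carbon). Among the measured compounds shown here, one measured step bears on this: methoxy in place of hydrogen gave a 7.5-fold higher number from compound 2 to compound 3 (0.88 log units; beyond the scatter) as a modest change. For the measured compounds named here, no chloro compound has been measured, so this is only a rough guide. The expected change in this assay is modest and downward, a 2.7-fold lower number from compound 3 to compound 4 (0.43 log units; beyond the scatter) as an estimate. The estimate for compound 4 is 3000 nM with an expected range of 800 nM to 9500 nM in this read-out.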

Compound 4, half-maximal inhibitory concentration: 758 nM
Compound 4: middle estimate off by 4.0-fold (0.60 log units), on the high side, outside the stated range (below it).
By their numbers in this assay, from the lowest: compounds 4 and 2 (each within the scatter of the next); then compounds 3 and 1 (each within the scatter of the next).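

In this assay, chloro in place of methoxy gives an 11-fold lower number from compound 3 to compound 4 (1.03 log units; beyond the scatter), while chloro in place of hydrogen gives a 1.4-fold lower number from compound 2 to compound 4 (0.15 log units; within the scatter). At this place, para to a large group, chloro and hydrogen therefore cannot be told apart, and of the three groups only methoxy stands apart. Nothing at hand accounts for this difference.

Going by these compounds, whether an ethoxy group, an amine or a carboxylic acid at this place would follow methoxy, or follow chloro and hydrogen, stays open. Also open, on these data alone, is whether the same difference between chloro and methoxy would hold on the core of compound 1.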